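Low Cytotoxicity and a Fluorine Swap

This account rests on a few compounds, and the source may have more. Where it says the series, first, only, none or still open, it means among the compounds named here.

- Compound 1 `COc1ccc(S(=O)(=O)NN2C(=S)S/C(=C\c3ccc(Cl)c(Cl)c3)C2O)cc1` gives > 100000 nM as a limit
- Compound 2 `COc1cccc(/C=C2\SC(=S)N(NS(=O)(=O)c3ccccc3)C2=O)c1` gives > 100000 nM as a limit

In a functional assay on HFF cells (Homo sapiens) for cytotoxicity (on this read-out lower numbers stand for stronger inhibition and higher numbers for weaker inhibition), neither measured compound gives a number, and the record so far comes down to the limit of > 100000 nM in this assay, at which 2 of the 2 values shown sit, and nothing more. Compound 2 stands only at a limit, and so does compound 1.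

Compound 3 `O=C1/C(=C/c2ccc(F)cc2F)SC(=S)N1NS(=O)(=O)c1ccccc1` has not yet been measured. It keeps the core of compound 2 and alters one group. The change is 2,4-difluorophenyl in place of 3-methoxyphenyl on a double-bonded chain carbon bound to a double-bonded ring carbon and it puts 2,4-difluorophenyl in place of 3-methoxyphenyl on a double-bonded chain carbon bound to a double-bonded ring carbon.

Among the measured compounds shown here, no pair of measured compounds differs in one place only, so no measured step sizes this swap. The closest guide is compound 2, whose reading of > 100000 nM is a limit. The expected change is a number no higher from compound 2 to compound 3 (the limit leaves the size open) in this assay with nothing beyond the scatter in either direction. Compound 3 is estimated at 100000 nM within an expected range from 40000 nM to 250000 nM and may well give only a limit.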

Compound 3, half-maximal inhibitory concentration: > 100000 nM
Compound 3 was reported as a limit (the forecaster's own chance of this, stated with the estimate: 80%); the middle value lies on the limit itself.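

In this assay compound 3 gives > 100000 nM, which is a limit and not a number. Compound 2 also stands only at a limit, and the step from compound 2 to compound 3 cannot be read. The compounds shown leave open whether putting 2,4-difluorophenyl in place of 3-methoxyphenyl changes cytotoxicity at all.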